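The source may report more compounds than this note shows. Statements on the series, on what has been measured and on what is new or still open speak of the compounds shown alone.

So far, two compounds have been measured in a functional assay on NCI-H226 cells (Homo sapiens) for inhibition, read by sulforhodamine B assay, with a stated time of 48 h, tested at 10 uM (a lower number here means less inhibition of growth, a higher number more inhibition of growth at the concentration tested), and give these values:

- Compound 1 (`COc1ccc(-c2nc3sc(-c4ccccc4)cn3n2)cc1`) gives 23%
- Compound 2 (`Clc1ccc(-c2cn3nc(-c4ccccc4)nc3s2)cc1`) gives 32%

Compound 2 gives 32% in this assay and lies within the usual scatter of compound 1 at 23%, so neither can be placed ahead of the other. Compound 3 (`c1ccc(-c2nc3sc(-c4ccccc4)cn3n2)cc1`) departs from compound 2 by a single change: hydrogen in place of chloro on an aromatic carbon, which turns the 4-chlorophenyl into phenyl (hydrogen in place of chloro on an aromatic carbon). The rest of the structure stays as it is. Among the compounds with values here, no two measured compounds differ in one place only, so the data hold no direct measure of such a change. The expectation therefore rests on the narrow spread so far, with compound 1 at 23% and compound 2 at 32%. The expected result is no step beyond the scatter, and the estimated a number 7 percentage points lower from compound 2 to compound 3 (within the scatter) is small and slightly downward. In this assay compound 3 is estimated at 25%, with an expected range of 10% to 40%.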

Compound 3, percent growth inhibition at one concentration: 27%
The estimate for compound 3 lay 2 percentage points below the measured number; measured number inside the range.
By their numbers in this assay, from the lowest: compounds 1, 3 and 2 (each within the scatter of the next).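

With compound 3, the series gains its first direct comparisons. This compound carries plain phenyl groups where compound 1 has a methoxy and compound 2 has a chloro. In this assay, hydrogen in place of chloro on an aromatic carbon, para to a large group, gives a number 5 percentage points lower from compound 2 to compound 3 (within the scatter), so this change from 4-chlorophenyl to phenyl has no effect that can be told from the scatter; hydrogen in place of methoxy gives a number 4 percentage points higher from compound 1 to compound 3 (within the scatter), which likewise stays within the scatter, although the methoxy stands on the other phenyl ring of the shared core. Neither substituent can therefore be separated from hydrogen at its own place in this single-concentration read-out, and nothing available offers an explanation for these small differences.

Going by these compounds, what a group of another kind, such as an amine, a carboxylic acid or a longer alkyl chain, would do at either of these places remains open. On these data alone, it is also open whether chloro and methoxy would give the same result if each stood on the other phenyl ring, or whether both rings could carry a substituent at once.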